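Swapping fluoro for difluoromethyl on a shared core

The source may report more compounds than this note shows. Statements on the series, on what has been measured and on what is new or still open speak of the compounds shown alone.

Measured so far in a physicochemical assay for lipophilicity; a lower number here means a more polar compound, a higher number a more lipophilic compound
- compound 1 `CC(=O)NCc1cccc(Cn2nc(NS(=O)(=O)c3ccc(Cl)s3)c3ccccc32)c1` gives 3.3
- compound 2 `CC(=O)NCc1cccc(Cn2nc(NS(=O)(=O)c3ccc(Cl)s3)c3c(F)cccc32)c1` gives 3
- compound 3 `CC(=O)NCc1cccc(Cn2nc(NS(=O)(=O)c3ccc(Cl)s3)c3c(C(C)O)cccc32)c1` gives 2.7

All three compounds share one core and differ only in the group on a single aromatic carbon. Compound 2 at 3 cannot be told apart from either of the other two, since its steps to both lie within the scatter. Only compound 1 and compound 3 differ clearly, with a number 0.60 log units lower from compound 1 to compound 3 (beyond the scatter) as the largest change seen here.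

The next compound, compound 4 `CC(=O)NCc1cccc(Cn2nc(NS(=O)(=O)c3ccc(Cl)s3)c3c(C(F)F)cccc32)c1`, carries difluoromethyl in place of fluoro on an aromatic carbon and keeps everything else. Within the data shown here, two measured steps bear most directly on this swap. One is a number 0.30 log units lower from compound 1 to compound 2 (within the scatter) and shows what fluoro does when it replaces hydrogen. The other is a number 0.30 log units lower from compound 2 to compound 3 (within the scatter) and shows fluoro leaving for a different group. Among the measured compounds shown here, neither is a large step, but no measured step has difluoromethyl entering, so the direction rests on thin evidence. In this assay a slight upward lean is expected, and the estimated step (a number 0.20 log units higher from compound 2 to compound 4 (within the scatter)) stays small. Compound 4 is expected at 3.2 (range 2.8 to 3.6).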

Compound 4, distribution coefficient: 3.7
Estimate against measurement, compound 4: 0.50 log units below; the measured number lies above the stated range.
By their numbers in this assay, from the lowest: compounds 3, 2 and 1 (each within the scatter of the next, the first and the last beyond it); then compound 4.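

In this assay, among these compounds, the earlier groups on this aromatic carbon left the number level with that of hydrogen or took it lower, while difluoromethyl is the first to take it clearly above hydrogen (a number 0.40 log units higher from compound 1 to compound 4 (beyond the scatter)), so changes at this one position can move the number in either direction. Both fluoro and difluoromethyl contain fluorine, yet they are clearly apart (a number 0.70 log units higher from compound 2 to compound 4 (beyond the scatter)), which means that the presence of fluorine alone does not tell where a compound in this small set will fall. Among the compounds shown here, the range at this position is also wider than the earlier compounds showed, with compound 3 and compound 4 now marking its two ends (a number 1.00 log units higher from compound 3 to compound 4 (beyond the scatter)).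

No measurement shown here explains why these groups differ. Still open is whether trifluoromethyl, a plain methyl or an amine on the same carbon would fall above, below or among these four compounds, and whether difluoromethyl would have a similar effect on another carbon of the shared core.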